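Sulfamate amide series: benzyl for piperidinyl at compound 4

A few compounds are considered here, and "the series" means these few. Any claim that something is new, unique, unknown or untested is made for them only; others in the source may bear on it.

Measured so far:
compound 1 `NS(=O)(=O)Oc1ccc2c(c1)CN(C(=O)c1ccc(N3CCC(N4CCCCC4)CC3)cc1)CC2` with 8.5%
compound 2 `CC(C)CCN(CCC(C)C)c1ccc(C(=O)N2CCc3ccc(OS(N)(=O)=O)cc3C2)cc1` with 47%
compound 3 `CCN(Cc1cccnc1)c1cccc(C(=O)N2CCc3ccc(OS(N)(=O)=O)cc3C2)c1` with 14.3%

In an assay on HEK293 cells for inhibition of Steryl-sulfatase (Homo sapiens), tested at 0.1 uM (a higher number here means a stronger effect of the compound at the concentration tested, a lower number a weaker effect), compound 1 gives the lowest of the three numbers; compound 3 sits within the scatter of it, while compound 2 lies beyond the scatter above it. Compound 4 `NS(=O)(=O)Oc1ccc2c(c1)CN(C(=O)c1ccc(N3CCC(Cc4ccccc4)CC3)cc1)CC2` keeps the shared core of compound 1 and differs only by benzyl in place of piperidin-1-yl on a saturated ring carbon. Going by the values given here, no step between measured compounds covers this change, so the expectation rests on the spread of the three values alone. The expected step is a number 13.5 percentage points higher from compound 1 to compound 4 (beyond the scatter), upward but modest, and a result within the scatter of compound 1 remains possible. For compound 4 the estimate is 22%, with a range from 6% to 45%.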

Compound 4, a percentage reported as inhibition, at one concentration (the size of the read-out at that concentration, not a potency): 41.4%
Beside the measured number, compound 4's estimate is 19.4 percentage points below it, within the range that was stated.
By their numbers in this assay, from the lowest: compounds 1 and 3 (each within the scatter of the next); then compounds 4 and 2 (each within the scatter of the next).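

In this assay, going by these compounds alone, the saturated ring carbon three ring bonds from the ring nitrogen proves sensitive to its substituent: benzyl in place of piperidin-1-yl gives a number 32.9 percentage points higher from compound 1 to compound 4 (beyond the scatter), the first single-change step. The exchange swaps a nitrogen-containing non-aromatic ring for an aromatic ring of carbon only, so the step alone cannot separate these two differences. No available measurement explains the step. Cyclohexylmethyl on the same carbon would separate ring aromaticity from the loss of nitrogen. Phenyl or the longer phenylethyl chain would test the length of the link.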